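Returning an aromatic ring to the sulfur of compound 2

The compounds below may be only part of what the source reports. "The series", "measured", "known", "first", "only" and "open" are said of these compounds alone.

Going by the values given here, compound 2 `C#CSc1nc2nc(C)cc(N3CC[C@@H](C)[C@@H](N(C)c4ncnc5[nH]ccc45)C3)n2n1` is the only member of this set with a numerical reading: in a functional assay on BGC-823 cells (Homo sapiens) for inhibition, read by MTT assay, with a stated time of 72 h (a higher number here means a weaker inhibitor, a lower number a stronger inhibitor), compound 2 gives 62100 nM. Compound 1 `Cc1cc(N2CC[C@@H](C)[C@@H](N(C)c3ncnc4[nH]ccc34)C2)n2nc(SCc3nc4ccccc4[nH]3)nc2n1` carries (1H-benzimidazol-2-yl)methyl on the same sulfur, and in this assay compound 1 reaches only the limit > 100000 nM. Among the compounds with values here, the single measured step, an at least 1.6-fold lower number from compound 1 to compound 2 (0.20 log units; that floor lies within the scatter), is the sole evidence on this position; it rests on the limit of > 100000 nM in this assay, at which 1 of the 2 values shown sits, and cannot be sized beyond its floor. Compound 3 `Cc1cc(N2CC[C@@H](C)[C@@H](N(C)c3ncnc4[nH]ccc34)C2)n2nc(SCc3ccc(F)cc3)nc2n1` differs from compound 2 by 4-fluorobenzyl in place of ethynyl on a sulfur. Within the data shown here, this brings an aromatic ring on the sulfur back, as in compound 1, so the one measured pair suggests a shift towards higher numbers in this assay, though its size is uncertain and may not exceed the scatter. Compound 3 is therefore expected to give about 100000 nM, within 40000 nM to 250000 nM. The expected step is a 1.6-fold higher number from compound 2 to compound 3 (0.21 log units; within the scatter).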

Compound 3, half-maximal inhibitory concentration: 44300 nM
Beside the measured number, compound 3's estimate is 2.3-fold (0.35 log units) above it, within the range that was stated.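

In this assay, a 1.4-fold lower number from compound 2 to compound 3 (0.15 log units; within the scatter) shows that exchanging ethynyl for 4-fluorobenzyl on the sulfur leaves compound 2 and compound 3 indistinguishable, so the return of an aromatic ring does not bring the shift towards higher numbers that the earlier pair seemed to suggest. Going by these compounds alone, the change from 1H-benzimidazol-2-yl to 4-fluorophenyl gives an at least 2.2-fold lower number from compound 1 to compound 3 (0.35 log units; beyond the scatter), the first step at this position beyond the scatter, and it shows that the identity of the ring on the saturated chain carbon matters, not merely its presence. Compound 1 stands at a limit of the assay, so this step has only a floor: the limit of > 100000 nM in this assay, at which 1 of the 3 values shown sits.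

As far as these compounds go, it remains open whether the fluorine contributes to the reading of compound 3, which a plain benzyl on the sulfur would address. Also open, from the compounds shown here alone, is how a pyridin-2-ylmethyl group, or a longer chain ending in an amine or a carboxylic acid, would read at this sulfur.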